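Same Chain Change on Two Cores: Expected Cytotoxicity

This account rests on a few compounds, and the source may have more. Where it says the series, first, only, none or still open, it means among the compounds named here.

Three compounds have been measured in an ADME assay on L6 cells (Rattus norvegicus) for cytotoxicity, read by resazurin assay, with a stated time of 70 h; on this read-out higher numbers stand for weaker inhibition and lower numbers for stronger inhibition:
Compound 1 `c1ccc(OCCCCCOc2cccc(-c3cc4cc(C5=NCCN5)ccc4o3)c2)cc1` gives 2600 nM.
Compound 2 `c1ccc(OCCCCCCOc2cccc(-c3cc4cc(C5=NCCN5)ccc4o3)c2)cc1` gives 2500 nM.
Compound 3 `N=C(N)c1ccc2cc(-c3ccc(OCCCCCOc4ccccc4)cc3)oc2c1` gives 9000 nM.

Compound 4 `N=C(N)c1ccc2cc(-c3ccc(OCCCCCCOc4ccccc4)cc3)oc2c1` has not yet been measured. Compound 1 and compound 2 differ by phenoxymethyl in place of phenoxy on a saturated chain carbon, five bonds along the chain from an oxygen on an aromatic ring. Compound 3 and compound 4 differ by phenoxymethyl in place of phenoxy on a saturated chain carbon, five bonds along the chain from an oxygen on an aromatic ring, the same change at the same place. The difference between the core of compound 1 and the core of compound 3 is not broken down here; their values simply show compound 3 with the higher number, beyond the scatter. Because the earlier step of a 1.0-fold lower number from compound 1 to compound 2 (0.02 log units; within the scatter) stayed within the scatter, the same is expected of compound 4, namely no change at the digits printed from compound 3 to compound 4 (within the scatter). Compound 4 is therefore estimated at 9000 nM, expected to fall between 4500 nM and 18000 nM.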

Compound 4, half-maximal inhibitory concentration: 8000 nM
Compound 4: middle estimate off by 1.1-fold (0.05 log units), on the high side; the range from low to high includes it.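

In this assay the new step reads a 1.1-fold lower number from compound 3 to compound 4 (0.05 log units; within the scatter). Set beside the earlier step, the change from phenoxy to phenoxymethyl gives a matching result on the two cores: the same change on two cores in this assay, a 1.0-fold lower number (0.02 log units; within the scatter) from compound 1 to compound 2 and a 1.1-fold lower number (0.05 log units; within the scatter) from compound 3 to compound 4, 1.1-fold (0.03 log units) apart, within the scatter of two such steps. This shows that, on these two cores and in this one assay, the change carried over without moving the number beyond the scatter, but it does not show that the same would hold on a third core or in a different assay.

The compounds shown leave open what a longer chain, such as 3-phenoxypropyl in place of phenoxymethyl, would do. They also leave open whether an amine or a carboxylic acid in place of the phenoxy group would behave alike on both cores.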